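Swapping the chloro of compound 2 for piperazin-1-yl

A few compounds are considered here, and "the series" means these few. Any claim that something is new, unique, unknown or untested is made for them only; others in the source may bear on it.

Of the compounds shown here, three sharing one core have been tested in a functional assay on G-361 cells (Homo sapiens) for cytotoxicity, read by MTT assay, with a stated time of 3 days; on this read-out lower numbers stand for stronger inhibition and higher numbers for weaker inhibition. Compound 1 `N#Cc1c(O)nc(SCc2nc3ccccc3[nH]2)nc1-c1ccccc1` gives 3.43 nM, compound 2 `N#Cc1c(Cl)nc(SCc2nc3ccccc3[nH]2)nc1-c1ccccc1` gives 12.5 nM, and compound 3 `N#Cc1c(NC(N)=S)nc(SCc2nc3ccccc3[nH]2)nc1-c1ccccc1` gives 5.81 nM. Compound 2 therefore stands with the highest number of the three, a modest 3.6-fold higher number from compound 1 to compound 2 (0.56 log units; beyond the scatter) and a modest 2.2-fold lower number from compound 2 to compound 3 (0.33 log units; beyond the scatter) separating it from its neighbours.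

The next compound, compound 4 `N#Cc1c(-c2ccccc2)nc(SCc2nc3ccccc3[nH]2)nc1N1CCNCC1`, differs from compound 2 in one place: piperazin-1-yl in place of chloro on an aromatic carbon. For the measured compounds named here, two measured steps bear on this. The step of a 3.6-fold higher number from compound 1 to compound 2 (0.56 log units; beyond the scatter) shows that putting chloro in this position raised the number, and the step of a 2.2-fold lower number from compound 2 to compound 3 (0.33 log units; beyond the scatter) shows that replacing chloro with a group bearing a hydrogen-bond donor brought it down again. Piperazin-1-yl likewise carries a hydrogen-bond donor and acceptors, so a modest fall in this assay is expected, although a result within the scatter would not be surprising. Compound 4 is accordingly estimated at 6 nM, within a range of 2.5 nM to 15 nM, an expected 2.1-fold lower number from compound 2 to compound 4 (0.32 log units; beyond the scatter).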

Compound 4, half-maximal inhibitory concentration: 2.5 nM
The estimate for compound 4 lay 2.4-fold (0.38 log units) above the measured number; measured number inside the range.
By their numbers in this assay, from the lowest: compounds 4, 1 and 3 (each within the scatter of the next, the first and the last beyond it); then compound 2.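

Piperazin-1-yl in place of chloro gives a 5.0-fold lower number from compound 2 to compound 4 (0.70 log units; beyond the scatter) in this assay and shows that this aromatic carbon, next to the ring nitrogen and ortho to a cyano group, can carry a six-membered non-aromatic ring without any rise in the number. The ring also compares well with the open-chain group of compound 3, with a 2.3-fold lower number from compound 3 to compound 4 (0.37 log units; beyond the scatter) on this read-out, while hydroxy and piperazin-1-yl cannot be separated, with a 1.4-fold lower number from compound 1 to compound 4 (0.14 log units; within the scatter) as their step. No measurement here explains why these groups differ.

From the compounds shown here alone, whether the second ring nitrogen matters remains open, and morpholin-4-yl, with an oxygen in its place, or piperidin-1-yl, with a carbon, would test this. A simple dimethylamino group or a longer chain ending in an amine would show whether the ring itself is needed.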